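Replacing a small ring amine with a larger, amide-bearing one

This account rests on a few compounds, and the source may have more. Where it says the series, first, only, none or still open, it means among the compounds named here.

Compound 1 `Cc1nn([C@H](C)c2ccc(Cl)cc2Cl)c2nc(N3CC[C@H](N4CCC4)[C@H](C)C3)cnc12`: 58 nM
Compound 2 `C[C@@H]1CC(c2cnc3c(C#N)nn([C@H](C)c4ccc(Cl)cc4Cl)c3n2)=CC[C@@H]1N1CCC[C@H]1CO`: 40 nM

In a functional assay on cells for antagonist activity at C-C chemokine receptor type 4 (Homo sapiens), read by fluorescence and calcium flux, with stated times of 2.5 s and 45 s (on this read-out lower numbers stand for stronger inhibition and higher numbers for weaker inhibition), compound 1 gives 58 nM, the higher of the two numbers, while compound 2 gives 40 nM, a gap that lies within the scatter. Compound 3 `Cc1nn([C@H](C)c2ccc(Cl)cc2Cl)c2nc(N3CC[C@H](N4CCC[C@H]4CCC(N)=O)[C@H](C)C3)cnc12` differs from compound 1 by 2-(2-carbamoylethyl)pyrrolidin-1-yl in place of azetidin-1-yl on a saturated ring carbon. Going by the values given here, no measured pair shows what such a change does here, so the expectation rests on compound 1 alone. The step from compound 1 to compound 3 is expected to be small, a 1.5-fold lower number from compound 1 to compound 3 (0.16 log units; within the scatter), not clearly beyond the scatter. Compound 3 is therefore estimated at 40 nM, with a range from 12 nM to 130 nM.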

Compound 3, half-maximal inhibitory concentration: 37 nM
For compound 3 the middle estimate is 1.1-fold (0.03 log units) above the measured one; the range from low to high includes it.
By their numbers in this assay, from the lowest: compounds 3, 2 and 1 (each within the scatter of the next).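

In this assay, the step is a 1.6-fold lower number from compound 1 to compound 3 (0.20 log units; within the scatter) when azetidin-1-yl gives way to 2-(2-carbamoylethyl)pyrrolidin-1-yl. Going by these compounds alone, this saturated ring carbon therefore accepts a much larger group carrying an amide without a clear loss of inhibition, which the earlier compounds could not show. No measurement given here accounts for this result. As far as these compounds go, whether the terminal amide matters remains open, and a carboxylic acid or an amine at the end of the chain would test this. The role of chain length and of the defined stereocentre also remains unresolved.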